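Aryl swap on the chain: compound 2 to compound 3

The compounds below may be only part of what the source reports. "The series", "measured", "known", "first", "only" and "open" are said of these compounds alone.

In a functional assay on SW-620 cells (Homo sapiens) for cytotoxicity, read by MTT assay, with stated times of 4 h and 72 h, tested at 2 uM (a higher number here means a weaker inhibitor, a lower number a stronger inhibitor), compound 1 `COc1ccc(/C=C/C(=O)c2ccc(Nc3cc(C)nc4nc(SCc5nc6ccccc6[nH]5)nn34)cc2)cc1` gives 170 nM and compound 2 `Cc1cc(Nc2ccc(C(=O)/C=C/c3ccccc3F)cc2)n2nc(SCc3nc4ccccc4[nH]3)nc2n1` gives 250 nM as the other measured number, so compound 2 sits within the scatter of compound 1 and holds no separate rank. Compound 3 `Cc1cc(Nc2ccc(C(=O)/C=C/c3cccc(Cl)c3)cc2)n2nc(SCc3nc4ccccc4[nH]3)nc2n1` carries 3-chlorophenyl in place of 2-fluorophenyl on a double-bonded chain carbon bound to a double-bonded chain carbon, a change counted as 3-chlorophenyl in place of 2-fluorophenyl on a double-bonded chain carbon bound to a double-bonded chain carbon and the only difference between the two. For the measured compounds named here, the one measured step at this place is a 1.5-fold higher number from compound 1 to compound 2 (0.17 log units; within the scatter) for 2-fluorophenyl in place of 4-methoxyphenyl, and it lies within the scatter. Going by the values given here, no measured compound yet carries 3-chlorophenyl, so the evidence is thin and no move beyond the scatter is expected. The estimated move is a 1.1-fold lower number from compound 2 to compound 3 (0.06 log units; within the scatter) and stays inside the scatter. For compound 3 the expected value is 220 nM with an estimated range from 90 nM to 550 nM for now.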

Compound 3, half-maximal inhibitory concentration: 400 nM
Compound 3: middle estimate off by 1.8-fold (0.26 log units), on the low side, and the stated range covers the measured number.
By their numbers in this assay, from the lowest: compounds 1, 2 and 3 (each within the scatter of the next, the first and the last beyond it).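

In this assay, a 1.6-fold higher number from compound 2 to compound 3 (0.20 log units; within the scatter) stays within the scatter, so 3-chlorophenyl and 2-fluorophenyl cannot be told apart on a double-bonded chain carbon bound to a double-bonded chain carbon. The aryl group at this place does register in the read-out, since a 2.4-fold higher number from compound 1 to compound 3 (0.37 log units; beyond the scatter) is a modest move, the only one here beyond the scatter, although compound 2 lies within the scatter of both compound 1 and compound 3. No measurement on these compounds accounts for that step.

Because the aryl groups differ in both substituent and ring position, the compounds shown do not separate the contribution of the substituent from that of its position. As far as these compounds go, it also remains open whether a dimethylamino group or a carboxylic acid on this phenyl ring would extend the spread of values beyond that seen with 4-methoxyphenyl and 3-chlorophenyl.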